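Swapping the Ring-Nitrogen Substituent of Compound 1

The source may hold more compounds than are shown below. What is called first, only, known or untested is meant among the compounds shown, and "the series" means these compounds.

Compound 1 `O=C(c1cccnc1)N1CCC(NS(=O)(=O)c2cc(S(=O)(=O)c3ccccc3)ccc2C(F)(F)F)CC1` was measured in an assay on U2OS cells for inhibition of secreted frizzled-related protein 1 (Homo sapiens), read by a luciferase reporter, with a stated time of 18 h (on this read-out lower numbers stand for an effect already at smaller amounts and higher numbers for an effect only at larger amounts of compound), and gives 120 nM. Among the three compounds measured, compound 1 holds the second highest number. Its nearest neighbour is compound 2 `CN(C)c1ccc(C(=O)N2CCC(NS(=O)(=O)c3cc(S(=O)(=O)c4ccccc4)ccc3C(F)(F)F)CC2)cn1`, which gives 70 nM; the step of a 1.7-fold lower number from compound 1 to compound 2 (0.23 log units; within the scatter) shows how close the two lie. Furthest away is compound 3 `O=S(=O)(NC1CCN(S(=O)(=O)c2cccc(-c3nnn[nH]3)c2)CC1)c1cc(S(=O)(=O)c2ccccc2)ccc1C(F)(F)F`, which gives 1200 nM, a number well apart from that of compound 1.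

Compound 4 `CC(C)(O)CCN1CCC(NS(=O)(=O)c2cc(S(=O)(=O)c3ccccc3)ccc2C(F)(F)F)CC1` has not yet been measured. It differs from compound 1 in one place: 3-hydroxy-3-methylbutyl in place of (pyridin-3-yl)carbonyl on an amine nitrogen in a ring. Among the compounds with values here, the only measured step, from compound 1 to compound 2, touches the aromatic ring that leaves in compound 4 but keeps the carbonyl on the ring nitrogen, so it says little about removing that whole group. Within the data shown here, compound 3 carries a different substituent on the same nitrogen, and its number, set beside that of compound 1, shows that changes at this position can cost a great deal, though no single step isolates that change.

Among the measured compounds shown here, with no directly comparable step, compound 4 is expected to give 300 nM, with a range from 80 nM to 1500 nM. This corresponds to an expected 2.5-fold higher number from compound 1 to compound 4 (0.40 log units; beyond the scatter), a modest loss that may yet fall within the scatter.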

Compound 4, half-maximal effective concentration: 630 nM
The estimate for compound 4 lay 2.1-fold (0.32 log units) below the measured number, within the range that was stated.
By their numbers in this assay, from the lowest: compounds 2 and 1 (each within the scatter of the next); then compounds 4 and 3 (each within the scatter of the next).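

Setting 3-hydroxy-3-methylbutyl in place of (pyridin-3-yl)carbonyl on an amine nitrogen in a ring gives, in this assay, a 5.3-fold higher number from compound 1 to compound 4 (0.72 log units; beyond the scatter), the first step that reads a change at this nitrogen on its own and shows that the number responds to what sits there. The same exchange starting from the (6-(dimethylamino)pyridin-3-yl)carbonyl group gives a 9.0-fold higher number from compound 2 to compound 4 (0.95 log units; beyond the scatter), so both acyl groups shown stand apart from the open chain by more than the scatter, whereas the two differ from each other only within it. No measurement bearing on the reason for these steps is available here.

In this exchange the aromatic ring and the carbonyl leave together and a hydroxyl-bearing chain enters, so the compounds shown leave open which of these changes carries the step. A benzyl group would keep an aromatic ring without the carbonyl, an acetyl group would keep the carbonyl without the ring, and a plain 3-methylbutyl chain would test the chain without its hydroxyl.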